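From benzyl to 3-fluorophenyl on a shared core

This account rests on a few compounds, and the source may have more. Where it says the series, first, only, none or still open, it means among the compounds named here.

- compound 1 `O=C1C=C(NCc2ccccc2)C(=O)c2c1nc1n2[C@H]2OC[C@@H](O)[C@H]2OC1`: > 8000 nM (a limit)
- compound 2 `O=C1C(Nc2ccccc2)=CC(=O)c2c1nc1n2[C@H]2OC[C@@H](O)[C@H]2OC1`: > 8000 nM (a limit)
- compound 3 `COc1ccccc1NC1=CC(=O)c2c(nc3n2[C@H]2OC[C@@H](O)[C@H]2OC3)C1=O`: 7460 nM

In a functional assay on HeLa cells (Homo sapiens) for inhibition, read by sulforhodamine B assay (on this read-out higher numbers stand for weaker inhibition and lower numbers for stronger inhibition), compound 1 gives > 8000 nM, which is a limit and not a number. Compound 1 thus sits at the limit of > 8000 nM in this assay, at which 2 of the 3 values shown sit.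

Compound 4 `O=C1C=C(Nc2cccc(F)c2)C(=O)c2c1nc1n2[C@H]2OC[C@@H](O)[C@H]2OC1` keeps the shared core, and its change is 3-fluorophenyl in place of benzyl on an amine nitrogen.

For the measured compounds named here, only one measured step bears on this, and only loosely: an at least 1.0-fold lower number from compound 2 to compound 3 (0.03 log units; that floor lies within the scatter). That step, methoxy in place of hydrogen on an aromatic carbon, gives no sign of a real change, so no step beyond the scatter is expected in this assay.

The expected step is a number no higher from compound 1 to compound 4 (the limit leaves the size open). Compound 4 is estimated at 8000 nM, with an expected range of 3000 nM to 20000 nM.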

Compound 4, half-maximal inhibitory concentration: 6440 nM
Estimate against measurement, compound 4: 1.2-fold (0.09 log units) above; low and high end bracket the measured number.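

Compound 1 carries only a limit, as does one other compound here: the limit of > 8000 nM in this assay, at which 2 of the 4 values shown sit.

Placing 3-fluorophenyl on this amine nitrogen gives an at least 1.2-fold lower number from compound 1 to compound 4 (0.09 log units; that floor lies within the scatter), so this change yields a measured number in this assay. A real gain in strength is neither shown nor ruled out, since the limit leaves its size open.

The compounds shown leave open what a longer chain in place of benzyl would do at this amine nitrogen. From the compounds shown here alone, the effect of an amine or a carboxylic acid on the phenyl ring also remains open.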